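Cyclobutyl to Hydroxyethyl on the Amide Nitrogen

A few compounds are considered here, and "the series" means these few. Any claim that something is new, unique, unknown or untested is made for them only; others in the source may bear on it.

Measured compounds in a functional assay on OVCAR-8 cells (Homo sapiens) for antiproliferative activity; a higher number here means a weaker inhibitor, a lower number a stronger inhibitor:
compound 1, `C=CC[C@@H]1C[C@@H](c2ccc(Cl)c(Cl)c2)[C@H](NC(=O)c2cc(-c3c(Cl)cnn3C)c(Cl)o2)CN1`, 990 nM
compound 2, `Cn1ncc(Cl)c1-c1cc(C(=O)N[C@@H]2CN[C@H](CC(N)=O)C[C@H]2c2ccc(Cl)c(Cl)c2)oc1Cl`, 1000 nM
compound 3, `Cn1ncc(Cl)c1-c1cc(C(=O)N[C@@H]2CN[C@H](CC(=O)NC3CCC3)C[C@H]2c2ccc(Cl)c(Cl)c2)oc1Cl`, 610 nM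

Compound 3 gives the lowest number of the three in this assay, but its separation from compound 1, a 1.6-fold lower number from compound 1 to compound 3 (0.21 log units; within the scatter), and from compound 2, a 1.6-fold lower number from compound 2 to compound 3 (0.21 log units; within the scatter), each falls within the usual scatter, so the three compounds cannot be told apart on these numbers.

Compound 4 is `Cn1ncc(Cl)c1-c1cc(C(=O)N[C@@H]2CN[C@H](CC(=O)NCCO)C[C@H]2c2ccc(Cl)c(Cl)c2)oc1Cl`. It differs from compound 3 at the amide-type nitrogen whose other neighbour is the carbonyl carbon: 2-hydroxyethyl in place of cyclobutyl on an amide-type nitrogen.

The step that bears most directly on this change is a 1.6-fold lower number from compound 2 to compound 3 (0.21 log units; within the scatter), where cyclobutyl replaced hydrogen on that same nitrogen. The remaining steps, a 1.0-fold higher number from compound 1 to compound 2 (0.00 log units; within the scatter) and a 1.6-fold lower number from compound 1 to compound 3 (0.21 log units; within the scatter), also stayed within the scatter. All variation seen so far at this position, from vinyl through carbamoyl to cyclobutylcarbamoyl, left the read-out essentially unchanged. Compound 4 is therefore expected to show a step of a 1.3-fold higher number from compound 3 to compound 4 (0.12 log units; within the scatter), with no movement beyond the scatter in either direction. Compound 4 is expected to give about 800 nM, within a range of 400 nM to 1600 nM.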

Compound 4, half-maximal inhibitory concentration: 1450 nM
The estimate for compound 4 lay 1.8-fold (0.26 log units) below the measured number, within the range that was stated.
By their numbers in this assay, from the lowest: compounds 3, 1, 2 and 4 (each within the scatter of the next, the first and the last beyond it).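

In this assay, replacing cyclobutyl with 2-hydroxyethyl on the amide-type nitrogen gives a 2.4-fold higher number from compound 3 to compound 4 (0.38 log units; beyond the scatter), the first step among these compounds to pass beyond the scatter, though only modestly. The separation appears only between the two substituted amides: hydrogen on the same nitrogen cannot be told apart from either group, with a 1.6-fold lower number from compound 2 to compound 3 (0.21 log units; within the scatter) and a 1.5-fold higher number from compound 2 to compound 4 (0.16 log units; within the scatter), and the vinyl compound likewise stays within the scatter of the new compound, with a 1.5-fold higher number from compound 1 to compound 4 (0.17 log units; within the scatter). No measurement shown here accounts for the step between cyclobutyl and 2-hydroxyethyl.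

The compounds shown leave open whether this step goes with the loss of the four-membered carbon ring or with the arrival of the hydroxyl, and a plain ethyl group on that nitrogen would separate the two. Also open, as far as these compounds go, is what the chain end tolerates in this assay, which a 2-methoxyethyl chain, a 2-aminoethyl chain or a carboxylic acid at the same place could test.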